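Chain shortening in the series: compound 2 to compound 3

The compounds below may be only part of what the source reports. "The series", "measured", "known", "first", "only" and "open" are said of these compounds alone.

Measured in a functional assay on PC-3 cells (Homo sapiens) for antiproliferative activity, read by MTT assay, with a stated time of 48 h; a higher number here means a weaker inhibitor of growth, a lower number a stronger inhibitor of growth:
- Compound 1 `CCN(Cc1ccc(C(=O)NO)cc1)c1ncc(-c2ccc(C)cc2)s1`: 10300 nM
- Compound 2 `CCCCCCN(Cc1ccc(C(=O)NO)cc1)c1ncc(-c2ccc(C)cc2)s1`: 5270 nM

Among the measured compounds shown here, compound 2 and compound 1 are the only measured members, and their values lie within the scatter of each other, so compound 2 has no distinct standing yet. Compound 3 `CCCN(Cc1ccc(C(=O)NO)cc1)c1ncc(-c2ccc(C)cc2)s1` differs from compound 2 by hydrogen in place of propyl on a saturated chain carbon, three bonds along the chain from a nitrogen on an aromatic ring. Cut one bond further out, this reads hexyl to propyl, which gives compound 3 a chain shorter than that of compound 2 and longer than that of compound 1. For the measured compounds named here, the one measured step bearing on this is a 2.0-fold lower number from compound 1 to compound 2 (0.29 log units; within the scatter). It spans the change at hand, so no step beyond the scatter is expected in this assay. The expected step is a 1.4-fold higher number from compound 2 to compound 3 (0.15 log units; within the scatter). Compound 3 is estimated at 7400 nM, with an expected range of 3500 nM to 15000 nM.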

Compound 3, concentration for 50% growth inhibition: 9160 nM
For compound 3 the middle estimate is 1.2-fold (0.09 log units) below the measured one, and the stated range covers the measured number.
By their numbers in this assay, from the lowest: compounds 2, 3 and 1 (each within the scatter of the next).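

In this assay, a third chain length joins the series without separating it: the hexyl to propyl change gives a 1.7-fold higher number from compound 2 to compound 3 (0.24 log units; within the scatter), and extending the shorter chain gives a 1.1-fold lower number from compound 1 to compound 3 (0.05 log units; within the scatter). Among the compounds shown here, with these steps and the earlier one all within the scatter, no dependence on chain length can be read from compound 1, compound 2 and compound 3, and this position so far tolerates the change without a distinct result. No measured evidence bears on why the numbers stay together here.

On these data alone, whether a chain longer than hexyl, or a chain ending in an amine or a carboxylic acid, would give a step beyond the scatter remains open. Also open, as far as these compounds go, is whether this flat reading holds on a different core.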